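Swapping a methoxyethyl chain for isopropyl on a quinone core

A few compounds are considered here, and "the series" means these few. Any claim that something is new, unique, unknown or untested is made for them only; others in the source may bear on it.

Measured so far in a functional assay on L1210 cells (Mus musculus), with a stated time of 1 days; a higher number here means a more potent compound, by a factor of ten per unit of this negative logarithm, a lower number a less potent compound:
- compound 1 `CC1=C(N2CC2)C(=O)C(CC(C)OC(N)=O)=C(N2CC2)C1=O` gives 5.86
- compound 2 `CC1=C(N2CC2)C(=O)C(CCCOC(N)=O)=C(N2CC2)C1=O` gives 5.55
- compound 3 `COCCC1=C(N2CC2)C(=O)C(C)=C(N2CC2)C1=O` gives 5.19

Compound 3 sits lowest of the three. Its nearest neighbour is compound 2, and the step of a number 0.36 log units lower from compound 2 to compound 3 (beyond the scatter) goes beyond the scatter. The step of a number 0.67 log units lower from compound 1 to compound 3 (beyond the scatter) is larger still, so compound 3 is the least potent compound here by a clear margin.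

Compound 4 `CC1=C(N2CC2)C(=O)C(C(C)C)=C(N2CC2)C1=O` is the next, unmeasured member. Its change from compound 3 is isopropyl in place of 2-methoxyethyl on a double-bonded ring carbon. The 2-methoxyethyl chain leaves and an isopropyl group enters on the double-bonded ring carbon of the six-membered non-aromatic ring of carbon only.

Both measured steps that end at compound 3 describe shrinking or simplifying the side chain at this position, and both lowered the number in this assay: a number 0.67 log units lower from compound 1 to compound 3 (beyond the scatter) and a number 0.36 log units lower from compound 2 to compound 3 (beyond the scatter). Going by the values given here, compound 4 continues in that direction, shedding the single hydrogen-bond acceptor that compound 3 still carries. A further modest drop is therefore expected, though the two earlier steps were themselves modest and the new group is small, so the change might also fall within the scatter.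

For compound 4 in this assay the expected value is 4.95, with a range from 4.4 to 5.5, which corresponds to an expected step of a number 0.24 log units lower from compound 3 to compound 4 (within the scatter).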

Compound 4, logarithm of the reciprocal of the active concentration, log(1/C): 4.96
Beside the measured number, compound 4's estimate is 0.01 log units below it; the range from low to high includes it.
By their numbers in this assay, from the lowest: compounds 4 and 3 (each within the scatter of the next); then compound 2; then compound 1.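

In this assay, the isopropyl group carries no hydrogen-bond acceptor, whereas the 2-methoxyethyl chain carries one, yet the two compounds cannot be told apart (a number 0.23 log units lower from compound 3 to compound 4 (within the scatter)). At this double-bonded ring carbon, then, the oxygen of the 2-methoxyethyl chain shows no effect beyond the scatter. The chains ending in a carbamoyloxy group are another matter, since replacing them with isopropyl gives clear drops (a number 0.59 log units lower from compound 2 to compound 4 (beyond the scatter) and a number 0.90 log units lower from compound 1 to compound 4 (beyond the scatter)), and the second of these is the widest gap among the compounds shown, though nothing available explains why these gaps arise.

Going by these compounds, what remains open is whether the carbamoyloxy group itself accounts for the higher numbers, or whether a chain of similar length ending in a hydroxyl group or an amine would match them. A plain n-butyl or n-pentyl chain at the same carbon would help separate the effect of chain length from that of the end group, and a carboxylic acid there would test a quite different end group on the shared core.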